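Trading an acetyl for a methyl on a phenolic oxygen

The source may report more compounds than this note shows. Statements on the series, on what has been measured and on what is new or still open speak of the compounds shown alone.

Three compounds share a common core built from a bicyclic terpene-like fragment joined to an oxygen-rich aromatic ring. Compound 1 `C=C1[C@H](C)CCC[C@]1(C)CC/C(C)=C/CC1=C(O)C(=O)C=C(OC)C1=O` has an open quinone-type ring and gives 0.1 ug/mL in a functional assay on COLO 205 cells (Homo sapiens) for cytotoxicity, read by MTT assay; on this read-out lower numbers stand for stronger inhibition and higher numbers for weaker inhibition. Compound 2 `C=C1[C@H](C)CCC[C@]1(C)CC[C@@]1(C)C=Cc2c(O)c(OC)cc(OC)c2O1` closes that ring into a fused system and gives 0.26 ug/mL in this assay. Compound 3 `C=C1[C@H](C)CCC[C@]1(C)CC[C@@]1(C)C=Cc2c(OC(C)=O)c(OC(C)=O)cc(OC)c2O1` carries two acetyl groups on ring oxygens and gives 0.22 ug/mL in this assay, placing it second highest of the three numbers: its gap to compound 2 lies within the scatter, while compound 1 sits beyond the scatter at a lower number.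

Compound 4 `C=C1[C@H](C)CCC[C@]1(C)CC[C@@]1(C)C=Cc2c(OC(C)=O)c(OC)cc(OC)c2O1` is the next step. Relative to compound 3 it differs by methyl in place of acetyl on an oxygen on an aromatic ring, on an oxygen on an aromatic ring whose other neighbours are aromatic carbon. Because compound 2 gives 0.26 ug/mL and compound 3 gives 0.22 ug/mL despite differing more at these oxygens, the step of a 1.1-fold higher number from compound 3 to compound 4 (0.04 log units; within the scatter) is expected to be small, with no direction beyond the scatter. Compound 4 is therefore estimated at 0.24 ug/mL, within 0.12 ug/mL to 0.5 ug/mL.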

Compound 4, half-maximal inhibitory concentration: 0.53 ug/mL
Beside the measured number, compound 4's estimate is 2.2-fold (0.34 log units) below it; measured number above the stated range.
By their numbers in this assay, from the lowest: compound 1; then compounds 3 and 2 (each within the scatter of the next); then compound 4.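

Swapping the acetyl for a methyl on this oxygen is not a silent change in this assay: acetoxy to methoxy gives a 2.4-fold higher number from compound 3 to compound 4 (0.38 log units; beyond the scatter), which means weaker inhibition. The other single change into compound 4, acetyl in place of hydrogen on an oxygen on an aromatic ring, moves the same way, with a 2.0-fold higher number from compound 2 to compound 4 (0.31 log units; beyond the scatter), so both neighbours that differ from compound 4 in one place inhibit more strongly. Nothing measured here accounts for these steps.

As far as these compounds go, only acetyl, methyl and hydrogen appear on these oxygens, so the effect of a longer group, such as an ethyl ether or a propanoyl ester, remains open. A single pair for each change also cannot show whether either step would hold on a different core.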